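The source may report more compounds than this note shows. Statements on the series, on what has been measured and on what is new or still open speak of the compounds shown alone.

Measured compounds:
- compound 1, `Cn1nc(-c2ccccc2)cc1-c1ccc2[nH]ccc2c1`, in a functional assay (Cortical neurone cells, Rattus norvegicus, strain Sprague-Dawley) for cytotoxicity, read by XTT assay, tested at 10 uM, in the presence of a further agent that is not named here (on this read-out higher numbers stand for a weaker effect at the one concentration tested and lower numbers for a stronger effect), gives 56.8%
- compound 2, `COc1ccc(-c2cc(-c3ccccc3)n[nH]2)cc1`, in this assay gives 64.9%

For the measured compounds named here, compound 1 and compound 2 share a five-membered core carrying a phenyl group, but they differ in several places at once, so no single step between them is counted here. Of the two numbers, compound 2 gives the one that is nominally higher, yet the gap to compound 1 lies within the scatter of repeated measurements, and no difference between the two can be claimed on these data.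

The next compound, compound 3, `Clc1ccc(-c2cc(-c3ccccc3)n[nH]2)cc1`, is not yet measured in this assay. It departs from compound 2 in one place: chloro in place of methoxy on an aromatic carbon. The rest of the molecule is unchanged.

Going by the values given here, no measured pair in this set gives a step from which the effect of this exchange could be read off. With the two numbers shown lying within the scatter of each other, there is no basis for expecting a step of any particular direction, and the expected step is set at none beyond the scatter, a number 2.9 percentage points lower from compound 2 to compound 3 (within the scatter). For compound 3 the estimated value is 62%, with an expected range from 45% to 80%.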

Compound 3, a percentage reported as activity, at one concentration (the size of the read-out at that concentration, not a potency): 56.5%
Compound 3: middle estimate off by 5.5 percentage points, on the high side, within the range that was stated.
By their numbers in this assay, from the lowest: compounds 3, 1 and 2 (each within the scatter of the next).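

For the compounds shown here, compound 3 gives the first step in this set that can be read at a single place: with chloro in place of methoxy on an aromatic carbon, para to a large group, this assay shows a number 8.4 percentage points lower from compound 2 to compound 3 (within the scatter). On this read-out, at the one concentration tested, the two groups cannot be told apart, even though one is a single chlorine atom and the other brings a carbon and an oxygen. This one exchange therefore gives no sign that the read-out depends on which of these two groups sits at this position, though it cannot speak for other groups there, and no further measurement bears on this result.

Going by these compounds, whether an amine, a carboxylic acid or a longer chain such as butoxy at this position would give a step beyond the scatter remains open, as does the result with plain hydrogen there. Also open, on these data alone, is what a single exchange elsewhere on the shared core would do, for instance a fluoro group on the other phenyl ring.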